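Series notes: compounds 1 to 3 and pending compound 4

The source may report more compounds than this note shows. Statements on the series, on what has been measured and on what is new or still open speak of the compounds shown alone.

Measured so far in a functional assay on HCT-116 cells (Homo sapiens) for inhibition, read by sulforhodamine B assay, with a stated time of 48 h; a lower number here means a stronger inhibitor, a higher number a weaker inhibitor:
Compound 1 `CCOC(=O)CCO/N=C(/c1ccc(OC)c(OC)c1OC)c1cccc2ccccc12` gives 10000 nM.
Compound 2 `COc1ccc(C(c2ccccc2O)c2cccc3ccccc23)c(OC)c1OC` gives > 20000 nM, which is a limit of the assay rather than a number.
Compound 3 `COc1ccc(C(O)(Cc2ccc(F)cc2)c2cccc3ccccc23)c(OC)c1OC` gives > 20000 nM, likewise a limit.

Compound 2 therefore stands at the limit of > 20000 nM in this assay, at which 2 of the 3 values shown sit. For the measured compounds named here, compound 1 is read as a number while compound 2 is not; no single-point step connects the two, so nothing more can be drawn from that pair.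

Compound 4 `COc1ccc(C(c2ccc(OCCO)cc2)c2cccc3ccccc23)c(OC)c1OC` is not yet measured. Relative to compound 2 it changes in one place: 4-(2-hydroxyethoxy)phenyl in place of 2-hydroxyphenyl on a saturated chain carbon bound to two aromatic carbons. Going by the values given here, no measured pair in this set carries a comparable change, so the size of the step has no anchor in the data. The expectation is a step of an at least 1.3-fold lower number from compound 2 to compound 4 (0.12 log units; that floor lies within the scatter), most likely within the scatter or a modest gain at best, since compound 2 itself sits at a limit. Compound 4 is expected near 15000 nM, with a range from 4000 nM to 40000 nM. A reading that is again only a limit is the more probable outcome for compound 4.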

Compound 4, half-maximal inhibitory concentration: > 20000 nM
Compound 4 gave a limit, no number; the forecaster's own chance of this, stated with the estimate: 60%; middle value at least 1.3-fold (0.12 log units) away from the limit.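

Compound 2 and compound 4 each stand at a limit of the assay rather than at a number, so no step can be read between them. Going by these compounds, whether 4-(2-hydroxyethoxy)phenyl in place of 2-hydroxyphenyl changes inhibition at all remains open.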